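A Tetrazolyl Group Added to an Inactive Starting Compound

A few compounds are considered here, and "the series" means these few. Any claim that something is new, unique, unknown or untested is made for them only; others in the source may bear on it.

Compound 1 `CCn1c(CNc2ccccc2)nnc1SCC(=O)Nc1ccccc1` was tested in an assay on isolated protein for inhibition of long-chain fatty acid transport protein 1 (Mus musculus); a higher number here means a weaker inhibitor, a lower number a stronger inhibitor. In this assay compound 1 gives > 10000 nM, which is a limit of the assay and not a number. Two relatives behave the same way. Compound 2 `CCOC(=O)c1ccc(NC(=O)CSc2nnc(CSCc3ccccc3)n2CC)cc1` gives > 10000 nM in this assay, again only a limit. Compound 3 `CCn1c(CNc2ccccc2)nnc1SCc1nc2cc(C)ccc2o1` gives > 10000 nM in this assay, also a limit. Going by the values given here, every value measured so far therefore sits at the limit of > 10000 nM in this assay, at which 3 of the 3 values shown sit, and compound 1 stands among them without measurable inhibition. Compound 4 `CCn1nnc(-c2ccc(NC(=O)CSc3nnc(CNc4ccccc4)n3CC)cc2)n1` differs from compound 1 by 2-ethyl-2H-tetrazol-5-yl in place of hydrogen on an aromatic carbon. Among the compounds with values here, no pair of measured compounds differing in one place exists, so no step size can be read from the data; the step is expected to be none beyond the scatter, a step that the limit leaves unreadable from compound 1 to compound 4. Compound 4 is estimated at 15000 nM, within 3000 nM to 60000 nM, most likely reported again as a limit.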

Compound 4, half-maximal inhibitory concentration: > 10000 nM
Compound 4 ended at the assay's limit; the forecaster's own chance of this, stated with the estimate: 75%; the middle value lies beyond the limit too.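

Compound 1 and compound 4 both end at a limit of the assay and not at a number, so no step between them can be read: the limit of > 10000 nM in this assay, at which 4 of the 4 values shown sit.

The compounds shown leave open which change, if any, would give a measurable value in this assay.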